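This account rests on a few compounds, and the source may have more. Where it says the series, first, only, none or still open, it means among the compounds named here.

Measured compounds:
compound 1, `Cc1ccc(-c2[nH]c3ccccc3c2C2=C(Br)C(=O)C(c3c(C)[nH]c4ccccc34)=C(Br)C2=O)cc1`, 3.25 ug/mL
compound 2, `COc1ccc2[nH]c(C)c(C3=C(Br)C(=O)C(c4c(-c5ccc(C)cc5)[nH]c5ccccc45)=C(Br)C3=O)c2c1`, 2.56 ug/mL
compound 3, `COc1ccc2[nH]c(C)c(C3=C(Cl)C(=O)C(Cl)=C(c4c(-c5ccc(C)cc5)[nH]c5ccccc45)C3=O)c2c1`, 2.31 ug/mL

Of the compounds shown here, three have been tested in a functional assay on MCF7 cells (Homo sapiens) for antiproliferative activity, read by CCK-8 assay, with a stated time of 48 h; a lower number here means a stronger inhibitor, a higher number a weaker inhibitor. Compound 1 gives 3.25 ug/mL, compound 2 gives 2.56 ug/mL, and compound 3 gives 2.31 ug/mL. All three numbers lie within the usual scatter of one another, so none of them can be ranked against the others.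

Compounds 2 and 1 differ in one place: hydrogen in place of methoxy on an aromatic carbon. The step this change makes in this assay is a 1.3-fold higher number from compound 2 to compound 1 (0.10 log units; within the scatter), a difference that lies within the scatter of repeated measurements.

Compound 4 has not yet been measured; its structure is `Cc1ccc(-c2[nH]c3ccccc3c2C2=C(Cl)C(=O)C(Cl)=C(c3c(C)[nH]c4ccccc34)C2=O)cc1`. It stands to compound 3 as compound 1 stands to compound 2: hydrogen in place of methoxy on an aromatic carbon. The place of the change is described in the same words in both pairs, so it is the same change, made this time on the core of compound 3. How the core of compound 3 differs from the core of compound 2 is not broken down here.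

Because the earlier step of a 1.3-fold higher number from compound 2 to compound 1 (0.10 log units; within the scatter) stayed within the scatter, and because compound 3 sits at 2.31 ug/mL, the step from compound 3 to compound 4 is expected to be small, about a 1.3-fold higher number from compound 3 to compound 4 (0.10 log units; within the scatter). Compound 4 is therefore estimated to give 2.9 ug/mL in this assay, most likely somewhere between 1.5 ug/mL and 5.5 ug/mL.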

Compound 4, half-maximal inhibitory concentration: 2.88 ug/mL
The estimate for compound 4 lay 1.0-fold (0.00 log units) above the measured number; low and high end bracket the measured number.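

In this assay, putting hydrogen in place of methoxy on the core of compound 3, which turns the 5-methoxy-2-methyl-1H-indol-3-yl group into 2-methyl-1H-indol-3-yl, makes only a small step, a 1.2-fold higher number from compound 3 to compound 4 (0.10 log units; within the scatter), and this step matches the one seen earlier on the other core: the same change on two cores in this assay, a 1.3-fold higher number (0.10 log units; within the scatter) from compound 2 to compound 1 and a 1.2-fold higher number (0.10 log units; within the scatter) from compound 3 to compound 4, 1.0-fold (0.01 log units) apart, within the scatter of two such steps. In these two pairs, then, the change carries from one core to the other with no visible difference in size, and neither step rises above the scatter of repeated measurements. This does not show that the methoxy group has any effect of its own on either core, since a real but small contribution could lie hidden in that scatter, and two pairs say nothing about how the change would behave on any further core in the series.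

The compounds shown leave open whether a different group at this place on the ring, such as an amine, a carboxylic acid or a longer alkoxy chain, would move the number beyond the scatter. Within the data shown here, they also leave open what the difference between the two cores contributes by itself, as no pair here isolates it.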